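The source may report more compounds than this note shows. Statements on the series, on what has been measured and on what is new or still open speak of the compounds shown alone.

Measured compounds:
compound 1 `Cc1ccc(CNC(=O)C(C)c2ccc(NS(C)(=O)=O)c(F)c2)c(N2CCC(C)CC2)n1`, 72.1 nM
compound 2 `CC1CCN(c2nc(-c3ccc(F)cc3)ccc2CNC(=O)C(C)c2ccc(NS(C)(=O)=O)c(F)c2)CC1`, 59 nM
compound 3 `CC1CC(C)CN(c2nc(C(F)(F)Cl)ccc2CNC(=O)C(C)c2ccc(NS(C)(=O)=O)c(F)c2)C1`, 1 nM

All three were tested in an assay on CHO cells for antagonist activity at transient receptor potential cation channel subfamily V member 1 (Homo sapiens), read by FLIPR; a higher number here means a weaker inhibitor, a lower number a stronger inhibitor. Compound 3 gives the lowest number of the three: compound 2 is its nearest neighbour, and compound 1 the furthest. Both gaps lie beyond the scatter, so compound 3 is the strongest inhibitor of this set. Among the measured compounds shown here, the only single-site step among the measured compounds is a 1.2-fold lower number from compound 1 to compound 2 (0.09 log units; within the scatter), which lies within the scatter.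

Compound 4 `CC(C(=O)NCc1ccc(C(F)(F)Cl)nc1OCc1cccnc1)c1ccc(NS(C)(=O)=O)c(F)c1` has not yet been measured. It differs from compound 3 in one place: (pyridin-3-yl)methoxy in place of 3,5-dimethylpiperidin-1-yl on an aromatic carbon. For the measured compounds named here, no measured step touches this position; the one step that is known changes a different part of the core and is itself within the scatter, so it does not tell how the present change will behave. Compound 3 also differs from compounds 1 and 2 in more than one place, so their values give no isolated reading of the group that leaves.

Going by the values given here, with no step to lean on, compound 4 is expected to move away from the very low number of compound 3 by a 10-fold higher number from compound 3 to compound 4 (1.00 log units; beyond the scatter) in this assay, with a wide range. The estimate for compound 4 is 10 nM, between 2 nM and 80 nM.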

Compound 4, inhibition constant: 14.6 nM
The estimate for compound 4 lay 1.5-fold (0.16 log units) below the measured number; low and high end bracket the measured number.
By their numbers in this assay, from the lowest: compound 3; then compound 4; then compounds 2 and 1 (each within the scatter of the next).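

In this assay, among the compounds shown here, putting (pyridin-3-yl)methoxy in place of 3,5-dimethylpiperidin-1-yl on the aromatic carbon next to the ring nitrogen gives a 15-fold higher number from compound 3 to compound 4 (1.16 log units; beyond the scatter), a large step and the first reading of any change at this position. This position is therefore sensitive to the group it carries, even though the count of heavy atoms stays the same and the change replaces a non-aromatic ring with an aromatic one, linked through oxygen, while the rest of the molecule is unchanged. Nothing measured here accounts for the size of the step.

The compounds shown leave open which part of the entering group goes with the higher number, since a benzyloxy group would test the ring nitrogen of the pyridine and a (pyridin-3-yl)methylamino group would test the oxygen link. They also leave open how much of the low number of compound 3 depends on the two methyl groups of its piperidine, which an unsubstituted piperidin-1-yl group at the same position would address.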